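Replacing 3,4-dichlorophenyl with 4-(trifluoromethyl)phenyl

The compounds below may be only part of what the source reports. "The series", "measured", "known", "first", "only" and "open" are said of these compounds alone.

compound 1 `COc1cc(C(=O)c2sc(-c3ccc(Cl)cc3)cc2N)cc(OC)c1OC` - 90 nM
compound 2 `COc1cc(C(=O)c2sc(-c3cccc([N+](=O)[O-])c3)cc2N)cc(OC)c1OC` - 17 nM
compound 3 `COc1cc(C(=O)c2sc(-c3ccc(Cl)c(Cl)c3)cc2N)cc(OC)c1OC` - 400 nM

In a functional assay on FM3A cells (Mus musculus) for antiproliferative activity (a higher number here means a weaker inhibitor, a lower number a stronger inhibitor), compound 3 stands highest of the three at 400 nM and is the weakest inhibitor measured so far. Going by the values given here, compound 4 `COc1cc(C(=O)c2sc(-c3ccc(C(F)(F)F)cc3)cc2N)cc(OC)c1OC` has no measurement yet. It carries 4-(trifluoromethyl)phenyl in place of 3,4-dichlorophenyl on an aromatic carbon next to the ring sulfur 4-(trifluoromethyl)phenyl in place of 3,4-dichlorophenyl on an aromatic carbon and otherwise keeps the core of compound 3.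

The most relevant measured change is a 4.4-fold higher number from compound 1 to compound 3 (0.65 log units; beyond the scatter) with chloro in place of hydrogen on an aromatic carbon. This modest step separates the 4-chlorophenyl group from the 3,4-dichlorophenyl group. The larger step of a 24-fold higher number from compound 2 to compound 3 (1.37 log units; beyond the scatter) shows how far this aryl group can move the number, but 3-nitrophenyl is a less close comparison for compound 4. The same holds for the modest step of a 5.3-fold lower number from compound 1 to compound 2 (0.72 log units; beyond the scatter) in this short series.

Compound 4 resembles compound 1 in bearing 4-substituted phenyl without the second chloro, so a modest step to a lower number is expected in this assay here. The expected change is a 3.1-fold lower number from compound 3 to compound 4 (0.49 log units; beyond the scatter) on this reasoning. Compound 4 is estimated at 130 nM with an expected range of 40 nM to 400 nM in this assay.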

Compound 4, half-maximal inhibitory concentration: 540 nM
For compound 4 the middle estimate is 4.2-fold (0.62 log units) below the measured one, and the stated range ends below it.
By their numbers in this assay, from the lowest: compound 2; then compound 1; then compounds 3 and 4 (each within the scatter of the next).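

In this assay the change from 3,4-dichlorophenyl to 4-(trifluoromethyl)phenyl, on the aromatic carbon next to the ring sulfur, stays within the scatter (a 1.4-fold higher number from compound 3 to compound 4 (0.13 log units; within the scatter)), so the two aryl groups cannot be told apart at this position. Compound 1 nevertheless remains clearly separate from compound 4 when trifluoromethyl replaces chloro (a 6.0-fold higher number from compound 1 to compound 4 (0.78 log units; beyond the scatter)), and compound 2 lies much further away (a 32-fold higher number from compound 2 to compound 4 (1.50 log units; beyond the scatter)), so a single group on the phenyl ring does not by itself keep the number near that of compound 1 or compound 2. Nothing available here explains these differences.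

Going by these compounds alone, still open is whether the low number of compound 2 belongs to the nitro group itself or to where it sits on the phenyl ring, as 3-nitrophenyl is the only group of its kind in this set. Also open, as far as these compounds go, is how the number responds at this position to a phenyl ring carrying an amine or a carboxylic acid, or to a phenyl ring with no added group at all.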